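This account rests on a few compounds, and the source may have more. Where it says the series, first, only, none or still open, it means among the compounds named here.

Measured compounds:
Compound 1, `CC(=O)Nc1ccc(NC(=O)C(F)(F)C(F)(F)C(F)(F)C(F)(F)C(F)(F)C(F)(F)C(=O)NO)cc1`, gives 13000 nM in an assay on isolated protein for inhibition of histone deacetylase 7 (Homo sapiens), read by fluorescence; on this read-out higher numbers stand for weaker binding and lower numbers for tighter binding.
Compound 2, `O=C(NO)C(F)(F)C(F)(F)C(F)(F)C(F)(F)C(F)(F)C(F)(F)C(=O)Nc1ccc(I)cc1`, gives 4100 nM.
Compound 3, `O=C(NO)C(F)(F)C(F)(F)C(F)(F)C(F)(F)C(F)(F)C(F)(F)C(=O)Nc1nc(-c2ccccc2)cs1`, gives 1400 nM.

Compound 3 stands lowest of the three numbers in this assay; compound 2 is nearest to it, compound 1 furthest. The three measured compounds share the same hydroxamic acid-bearing fluorinated chain and differ only in the group on the amide-type nitrogen at the far end. The steps there were all modest: a 3.2-fold lower number from compound 1 to compound 2 (0.50 log units; beyond the scatter), a 2.9-fold lower number from compound 2 to compound 3 (0.47 log units; beyond the scatter), and across both changes a 9.3-fold lower number from compound 1 to compound 3 (0.97 log units; beyond the scatter).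

Compound 4, `O=C(NO)C(F)(F)C(F)(F)C(F)(F)C(F)(F)C(F)(F)C(F)(F)C(=O)Nc1cccc(-c2ccccc2)c1`, keeps that chain and again alters only the group on the amide-type nitrogen: 3-phenylphenyl in place of 4-phenyl-1,3-thiazol-2-yl on an amide-type nitrogen. The three measured steps show that swapping this group moves the number by modest amounts in either direction, and none of them pairs a 3-phenylphenyl group with anything measured. Compound 4 is therefore expected to stay within a modest step of compound 3, most likely toward a somewhat higher number, with an expected step of a 1.8-fold higher number from compound 3 to compound 4 (0.25 log units; within the scatter). The estimate for compound 4 in this assay is 2500 nM, in a range from 800 nM to 8000 nM.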

Compound 4, dissociation constant: 14000 nM
Compound 4: the middle estimate sits 5.6-fold (0.75 log units) below what was measured; measured number above the stated range.
By their numbers in this assay, from the lowest: compound 3; then compound 2; then compounds 1 and 4 (each within the scatter of the next).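

Two aromatic rings on the amide-type nitrogen do not by themselves give the low number: in this assay, 3-phenylphenyl in place of 4-phenyl-1,3-thiazol-2-yl gives a clear loss (a 10-fold higher number from compound 3 to compound 4 (1.00 log units; beyond the scatter)), although both groups carry two aromatic rings. The new compound also falls behind the single-ring iodo compound (a 3.4-fold higher number from compound 2 to compound 4 (0.53 log units; beyond the scatter)), and it cannot be told apart from the acetamido compound (a 1.1-fold higher number from compound 1 to compound 4 (0.03 log units; within the scatter), within the scatter), so a larger group at this position brings no gain among these compounds. The low number of compound 3 therefore belongs to the 4-phenyl-1,3-thiazol-2-yl group as a whole and not to ring count or group size, with compound 1 and compound 4 showing that very different groups can land at the same level.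

The compounds shown do not separate the ring nitrogen and sulfur of the thiazole from the way the outer phenyl is attached, which a 4-phenylphenyl group or a 5-phenyl-1,3-thiazol-2-yl group would address. Nothing available here accounts for the size of the step from compound 3 to compound 4.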